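Swapping 4-hydroxyphenyl for 3-hydroxyphenyl in a three-aryl series

A few compounds are considered here, and "the series" means these few. Any claim that something is new, unique, unknown or untested is made for them only; others in the source may bear on it.

Measured so far:
compound 1 `Oc1ccc(-c2cc(-c3ccc(O)cc3)nc(-c3ccc(O)cc3)c2)cc1`, 5120 nM
compound 2 `Oc1ccc(-c2cc(-c3cccc(O)c3)cc(-c3ccc(O)cc3)n2)cc1`, > 50000 nM
compound 3 `Oc1ccc(-c2cc(-c3ccccc3O)cc(-c3ccccc3O)n2)cc1`, 8240 nM

In a functional assay on HCT-15 cells (Homo sapiens) for cytotoxicity, read by CCK-8 assay, with a stated time of 4 days (a higher number here means a weaker inhibitor, a lower number a stronger inhibitor), compound 1 gives 5120 nM. For compound 2 the assay gives only a limit, > 50000 nM. The step of an at least 9.7-fold higher number from compound 1 to compound 2 (0.98 log units; beyond the scatter) is a lower bound because of the limit of > 50000 nM in this assay, at which 1 of the 3 values shown sits. Compound 3 gives 8240 nM in this assay, and set against compound 1 the two values lie within the scatter; the difference between the two cores of compound 1 and compound 3 is not broken down here.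

Compound 4 `Oc1cccc(-c2cc(-c3ccccc3O)cc(-c3ccccc3O)n2)c1` is not yet measured. The change from compound 3 to compound 4 is 3-hydroxyphenyl in place of 4-hydroxyphenyl on an aromatic carbon, the same kind of change as 3-hydroxyphenyl in place of 4-hydroxyphenyl on an aromatic carbon, but the surroundings differ: in compound 4 the position is next to the ring nitrogen and meta to two 2-hydroxyphenyl groups, whereas in compound 2 it is opposite the ring nitrogen and meta to two 4-hydroxyphenyl groups.

The step from compound 3 to compound 4 in this assay is expected to be a weakening of about a 4.9-fold higher number from compound 3 to compound 4 (0.69 log units; beyond the scatter), resting on compound 1 to compound 2, an at least 9.7-fold higher number from compound 1 to compound 2 (0.98 log units; beyond the scatter). Compound 4 is thus estimated at 40000 nM in this assay, between 12000 nM and 120000 nM, with a fair chance that only a limit is returned.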

Compound 4, half-maximal inhibitory concentration: 3390 nM
For compound 4 the middle estimate is 12-fold (1.07 log units) above the measured one; the whole stated range lies above it.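

In this assay the swap of 4-hydroxyphenyl for 3-hydroxyphenyl gives a 2.4-fold lower number from compound 3 to compound 4 (0.39 log units; beyond the scatter), a gain on this core, whereas the same swap on the core of compound 1 brought a loss. The change therefore does not carry over between these two cores, either in size or in direction: the same change on two cores in this assay, an at least 9.7-fold higher number (0.98 log units; beyond the scatter) from compound 1 to compound 2 and a 2.4-fold lower number (0.39 log units; beyond the scatter) from compound 3 to compound 4, at least 23-fold (1.37 log units) apart, beyond the scatter of two such steps. As far as these compounds go, compound 2 is read only as a limit, so the size of the earlier step stays open, and two pairs do not show which difference between the cores sets the direction: the limit of > 50000 nM in this assay, at which 1 of the 4 values shown sits.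

Still open, from the compounds shown here alone, is whether the reversal follows the place of the changed ring, next to the ring nitrogen, or the two 2-hydroxyphenyl groups of compound 3 and compound 4. Also open, going by these compounds, is whether an amine or a carboxylic acid in place of the hydroxyl on that ring would respond to the core in the same way.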